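The source may hold more compounds than are shown below. What is called first, only, known or untested is meant among the compounds shown, and "the series" means these compounds.

Three compounds with a shared core differ only in the aromatic group on a ring nitrogen. In a functional assay on OVCAR-3 cells (Homo sapiens) for inhibition, read by MTT assay, with a stated time of 24 h (a higher number here means a weaker inhibitor, a lower number a stronger inhibitor), compound 3 (`CC1(C)[C@H]2CC[C@]1(C)N(Cc1cn(-c3ccc(O)cc3)nn1)C(=O)C2`) gives 410 nM and stands level, within the scatter, with compound 1 (`CC1(C)[C@H]2CC[C@]1(C)N(Cc1cn(-c3cccc(F)c3)nn1)C(=O)C2`) at 430 nM. Compound 2 (`CC1(C)[C@H]2CC[C@]1(C)N(Cc1cn(-c3ccccc3Br)nn1)C(=O)C2`) gives 140 nM and has the lowest number of the three.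

Compound 4 (`CC1(C)[C@H]2CC[C@]1(C)N(Cc1cn(-c3ccc(Cl)cc3)nn1)C(=O)C2`) has not yet been measured. It departs from compound 3 on an aromatic carbon para to a large group, with chloro in place of hydroxy, a change counted as chloro in place of hydroxy on an aromatic carbon and readable as 4-hydroxyphenyl to 4-chlorophenyl.

Within the data shown here, no measured step makes this exact exchange, and no chloro compound has a number yet, so the evidence is indirect. Replacing one halogen-bearing group with 4-hydroxyphenyl gave a 2.9-fold higher number from compound 2 to compound 3 (0.47 log units; beyond the scatter) but replacing the other gave a 1.0-fold lower number from compound 1 to compound 3 (0.02 log units; within the scatter) and the two halogen compounds themselves are separated by a 3.1-fold lower number from compound 1 to compound 2 (0.49 log units; beyond the scatter) (compound 1 thus goes against any general advantage of a halogen). A small move toward a lower number is therefore expected, possibly no larger than the scatter. The estimated step is a 1.5-fold lower number from compound 3 to compound 4 (0.18 log units; within the scatter) in this assay. For compound 4 the estimated value is 270 nM, with an expected range from 110 nM to 620 nM.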

Compound 4, half-maximal inhibitory concentration: 160 nM
Beside the measured number, compound 4's estimate is 1.7-fold (0.23 log units) above it; the range from low to high includes it.
By their numbers in this assay, from the lowest: compounds 2 and 4 (each within the scatter of the next); then compounds 3 and 1 (each within the scatter of the next).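

In this assay, among these compounds, chloro in place of hydroxy on an aromatic carbon para to a large group gives a 2.6-fold lower number from compound 3 to compound 4 (0.41 log units; beyond the scatter), the first step in this set that changes a single group on one fixed carbon, and it shows that the group at this place can move the number beyond the scatter. The 4-chlorophenyl group stands level with the 2-bromophenyl group, at a 1.1-fold higher number from compound 2 to compound 4 (0.06 log units; within the scatter), and departs from the 3-fluorophenyl group, at a 2.7-fold lower number from compound 1 to compound 4 (0.43 log units; beyond the scatter), so two halogen-bearing compounds now share the low end, while compound 1, also halogen-bearing, stands with compound 3 and goes against any rule that a halogen alone lowers the number. Nothing in these data gives a reason for these differences.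

The compounds shown leave open whether a methoxy group, an amine or a carboxylic acid on the same carbon would read like chloro or like hydroxy. They also leave open how far the position of a halogen on the phenyl ring counts apart from which halogen it is.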